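A few compounds are considered here, and "the series" means these few. Any claim that something is new, unique, unknown or untested is made for them only; others in the source may bear on it.

- compound 1 `COc1ccc(/C=C/C(=O)c2ccc(NC(C)=O)c(-c3ccc(F)cc3)c2)cc1OC` gives 15000 nM
- compound 2 `COc1ccc(/C=C/C(=O)c2ccc(N)c(-c3ccc(F)cc3)c2)cc1` gives 7580 nM
- compound 3 `COc1ccccc1/C=C/C(=O)c1cccc(-c2cccc(F)c2)c1` gives 18900 nM

All three numbers come from a functional assay on MCF7 cells (Homo sapiens) for cytotoxicity, read by sulforhodamine B assay, with a stated time of 48 h; on this read-out lower numbers stand for stronger inhibition and higher numbers for weaker inhibition. Compound 1 sits in the middle of the three, and its gaps to compound 2 and to compound 3 both lie within the usual scatter of repeated measurements. On these numbers, it is not clearly set apart from either one.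

The next compound to consider is compound 4 `COc1ccc(/C=C/C(=O)c2cccc(-c3ccc(F)cc3)c2)cc1OC`. It keeps the core of compound 1 but has hydrogen in place of acetamido on an aromatic carbon, ortho to a 4-fluorophenyl group and para to a large group: hydrogen in place of acetamido on an aromatic carbon.

Among the measured compounds shown here, no two measured compounds differ in one place only, so no measured step shows what this swap does. For the measured compounds named here, the only guide is indirect. Compound 3 also lacks a nitrogen-bearing group on the ring that carries its fluorophenyl group, and it gives 18900 nM. In this assay, therefore, no change beyond the scatter is expected, although this expectation rests on very little data. The expected step is a 1.2-fold lower number from compound 1 to compound 4 (0.06 log units; within the scatter). For compound 4, the estimated value is 13000 nM, with an expected range from 5500 nM to 30000 nM.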

Compound 4, half-maximal inhibitory concentration: 11600 nM
The estimate for compound 4 lay 1.1-fold (0.05 log units) above the measured number; the measured number falls inside the stated range.
By their numbers in this assay, from the lowest: compounds 2, 4, 1 and 3 (each within the scatter of the next, the first and the last beyond it).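

In this assay, hydrogen in place of acetamido on this aromatic carbon, ortho to a 4-fluorophenyl group and para to a large group, gives a 1.3-fold lower number from compound 1 to compound 4 (0.11 log units; within the scatter). Among the compounds shown here, this is the first step that changes one place only, and it shows that the acetamido group, with its 4 heavy atoms, its hydrogen-bond donor and its hydrogen-bond acceptor, can leave this core with no difference that stands out from the scatter of repeated measurements. No measured evidence bears on this result, so nothing can be said about the reason for it.

As far as these compounds go, what remains open is whether this position tolerates any group at all or only these two, since a single step that stays within the scatter cannot show how another group would behave here, such as an amine on this same core, a hydroxyl group, a carboxylic acid or a longer acyl chain. From the compounds shown here alone, it is also open whether the same swap would give a similar result on a core with a different pattern of methoxy groups or with the fluorine placed elsewhere.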